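A Methoxy Dihydroxyphenyl Ester Awaits Its Cytotoxicity Value

A few compounds are considered here, and "the series" means these few. Any claim that something is new, unique, unknown or untested is made for them only; others in the source may bear on it.

Compound 1 `CC(/C=C/C1=CCCCC1(C)C)=C\C=C\C(C)=C\COC(=O)c1cccc(O)c1O` gives only a limit in a toxicity assay on cells (Fibroblast, Homo sapiens) for cytotoxicity; on this read-out higher numbers stand for weaker inhibition and lower numbers for stronger inhibition: < 10000 nM, at the limit of < 10000 nM in this assay, at which 1 of the 3 values shown sits. Compound 2 `CC(/C=C/C1=CCCCC1(C)C)=C\C=C\C(C)=C\COC(=O)c1ccc(O)cc1O` gives 120000 nM in this assay, and compound 3 `CC(/C=C/C1=CCCCC1(C)C)=C\C=C\C(C)=C\COC(=O)c1cc(O)ccc1O` gives 14000 nM. The step of an at least 12-fold higher number from compound 1 to compound 2 (1.07 log units; beyond the scatter) shows that a changed hydroxyl pattern can shift the read-out strongly, whereas an at least 1.4-fold higher number from compound 1 to compound 3 (0.14 log units; that floor lies within the scatter) stays within the scatter. Compound 4 `COc1cc(O)c(C(=O)OC/C=C(C)/C=C/C=C(C)/C=C/C2=CCCCC2(C)C)c(O)c1` differs from compound 1 at the ester: a group of 10 heavy atoms (7 carbon, 3 oxygen; one six-membered aromatic ring of carbon only) in place of a group of 8 heavy atoms (6 carbon, 2 oxygen; one six-membered aromatic ring of carbon only), on a carbonyl carbon. Among the measured compounds shown here, no measured step carries this exact change; the nearest evidence comes from compound 2 and compound 3, whose steps from compound 1 span from no shift to a large one. Compound 4 is therefore expected to weaken modestly, a step of an at least 3.0-fold higher number from compound 1 to compound 4 (0.47 log units; beyond the scatter), with an estimate of 30000 nM between 8000 nM and 120000 nM.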

Compound 4, half-maximal inhibitory concentration: 14000 nM
Beside the measured number, compound 4's estimate is 2.1-fold (0.33 log units) above it; measured number inside the range.
By their numbers in this assay, from the lowest: compounds 3 and 4 (each within the scatter of the next); then compound 2. At a limit, below all of these: compound 1.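

The group of 10 heavy atoms on the carbonyl carbon cannot be told apart from 2,5-dihydroxyphenyl, with no change at the digits printed from compound 3 to compound 4 (within the scatter), yet it parts clearly from 2,4-dihydroxyphenyl, with an 8.6-fold lower number from compound 2 to compound 4 (0.93 log units; beyond the scatter). Against 2,3-dihydroxyphenyl, the comparison gives only a floor, with an at least 1.4-fold higher number from compound 1 to compound 4 (0.14 log units; that floor lies within the scatter). Compound 1 stands at a limit, not at a number: the limit of < 10000 nM in this assay, at which 1 of the 4 values shown sits.

As far as these compounds go, how far compound 1 truly lies from compound 4 remains open. So does how an amine or a carboxylic acid on this ester group would read in this assay.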